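The source may report more compounds than this note shows. Statements on the series, on what has been measured and on what is new or still open speak of the compounds shown alone.

Working notes on the series. The core of compound 1 `O=C1O[C@H]([C@@H](O)Cn2cc(-c3cc(C(F)(F)F)cc(C(F)(F)F)c3)nn2)C(OCc2ccccc2)=C1OCc1ccccc1` is shared throughout; in a functional assay on SW-620 cells (Homo sapiens) for antiproliferative activity, read by MTT assay, with a stated time of 72 h (on this read-out lower numbers stand for stronger inhibition and higher numbers for weaker inhibition), compound 1 gives 49200 nM. Within the data shown here, compound 2 `CCCCc1cn(C[C@H](O)[C@H]2OC(=O)C(OCc3ccccc3)=C2OCc2ccccc2)nn1` in this assay gives 47500 nM, one of only two numbers in hand, and it sits within the scatter of the number for compound 1. Compound 3 `CC(C)(C)OC(=O)N1CCN(C(=S)SCc2cn(C[C@H](O)[C@H]3OC(=O)C(OCc4ccccc4)=C3OCc3ccccc3)nn2)CC1` in this assay returns > 100000 nM, which is a limit of the assay rather than a number (the limit of > 100000 nM in this assay, at which 1 of the 3 values shown sits). Compound 4 `O=C1O[C@H]([C@@H](O)Cn2cc(CCCCl)nn2)C(OCc2ccccc2)=C1OCc1ccccc1` is not yet measured in this assay; it differs from compound 2 by chloro in place of methyl on a saturated chain carbon, three bonds along the chain from an aromatic carbon, butyl to 3-chloropropyl. The step is expected to be a 1.1-fold lower number from compound 2 to compound 4 (0.02 log units; within the scatter), nothing beyond the scatter in either direction. Compound 4 is accordingly expected in this assay near 45000 nM, within a range from 20000 nM to 100000 nM.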

Compound 4, half-maximal inhibitory concentration: 68500 nM
For compound 4 the middle estimate is 1.5-fold (0.18 log units) below the measured one; the range from low to high includes it.
By their numbers in this assay, from the lowest: compounds 2, 1 and 4 (each within the scatter of the next). At a limit, above all of these: compound 3.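

In this assay, chloro in place of methyl on a saturated chain carbon, three bonds along the chain from an aromatic carbon, gives a 1.4-fold higher number from compound 2 to compound 4 (0.16 log units; within the scatter) as the first step read at this position. The number therefore does not move beyond the scatter with this exchange. Nothing in hand bears on a cause for this step.

Open, as far as these compounds go, is whether an amine, a carboxylic acid or a longer chain at this position would move the number beyond the scatter in this assay.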